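Diaryl urea series: trifluoromethyl removal on the chlorophenyl ring

The compounds below may be only part of what the source reports. "The series", "measured", "known", "first", "only" and "open" are said of these compounds alone.

Measured so far in a functional assay on MDA-MB-231 cells (Homo sapiens) for cytotoxicity, read by MTT assay, with a stated time of 48 h; a lower number here means a stronger inhibitor, a higher number a weaker inhibitor:
compound 1 `O=C(NCCCCC(c1ccc(F)cc1)c1ccc(F)cc1)Nc1ccc(Cl)cc1`: 7680 nM
compound 2 `O=C(NCCCCC(c1ccc(F)cc1)c1ccc(F)cc1)Nc1ccc(Cl)c(C(F)(F)F)c1`: 3150 nM
compound 3 `Cc1ccc(C(CCCCNC(=O)Nc2ccc(Cl)c(C(F)(F)F)c2)c2ccc(C)cc2)cc1`: 2510 nM

Compound 2 and compound 1 share a core and differ by hydrogen in place of trifluoromethyl on an aromatic carbon; this change gave a 2.4-fold higher number from compound 2 to compound 1 (0.39 log units; beyond the scatter). Compound 3 carries a different core; how the two cores differ is not broken down here. Its value and that of compound 2 lie within the scatter of each other, so no order between them is claimed.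

Compound 4 `Cc1ccc(C(CCCCNC(=O)Nc2ccc(Cl)cc2)c2ccc(C)cc2)cc1` is not yet measured. It stands to compound 3 as compound 1 stands to compound 2, the difference being (hydrogen in place of trifluoromethyl on an aromatic carbon). Going by the values given here, for compound 4 the step is expected to be a 2.4-fold higher number from compound 3 to compound 4 (0.38 log units; beyond the scatter), which rests on the single measured instance of this change, a 2.4-fold higher number from compound 2 to compound 1 (0.39 log units; beyond the scatter). Among the compounds with values here, with only one precedent, the range is kept wide. Compound 4 is expected to give 6000 nM in this assay, between 3000 nM and 12000 nM.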

Compound 4, half-maximal inhibitory concentration: 17900 nM
Estimate against measurement, compound 4: 3.0-fold (0.47 log units) below, outside the stated range (above it).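

On the core of compound 3, the change from 4-chloro-3-(trifluoromethyl)phenyl to 4-chlorophenyl gives a 7.1-fold higher number from compound 3 to compound 4 (0.85 log units; beyond the scatter) in this assay and points the same way as on the core of compound 2. The direction of the step therefore carries across these two cores, but its size does not: the same change on two cores in this assay, a 2.4-fold higher number (0.39 log units; beyond the scatter) from compound 2 to compound 1 and a 7.1-fold higher number (0.85 log units; beyond the scatter) from compound 3 to compound 4, 2.9-fold (0.47 log units) apart, beyond the scatter of two such steps.
With only two instances, the data do not show which feature of the cores sets the size of the step, or how large it would be on a further core.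

Still open, on these data alone, is how the step would read with a nitrile or a methoxy group in place of the chloro group. Also open, as far as these compounds go, is whether it would hold on cores with a longer chain.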